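Compound 3 to compound 4: adding a second ring

This account rests on a few compounds, and the source may have more. Where it says the series, first, only, none or still open, it means among the compounds named here.

- compound 1 `CCNc1cc(-c2ccc(NC(=O)Nc3ccc(C)cc3)cc2C)ccn1` gives 22000 nM
- compound 2 `CCNc1cc(-c2ccc(NC(=O)Nc3ccc(OC)cc3)cc2C)ccn1` gives 25800 nM
- compound 3 `CCNc1cc(-c2ccc(NC(=O)Nc3ccc(C(F)(F)F)cc3)cc2C)ccn1` gives 19700 nM

All three were tested in a functional assay on BT-483 cells (Homo sapiens) for cytotoxicity, read by MTT assay, with a stated time of 24 h (on this read-out lower numbers stand for stronger inhibition and higher numbers for weaker inhibition), and compound 3 cannot be told apart from the other two. Compound 4 `CCNc1cc(-c2ccc(NC(=O)Nc3cccc4ccccc34)cc2C)ccn1` carries naphthalen-1-yl in place of 4-(trifluoromethyl)phenyl on an amide-type nitrogen.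

The measured steps that bear on this change are all small: a 1.2-fold higher number from compound 1 to compound 2 (0.07 log units; within the scatter), a 1.1-fold lower number from compound 1 to compound 3 (0.05 log units; within the scatter) and a 1.3-fold lower number from compound 2 to compound 3 (0.12 log units; within the scatter). Going by the values given here, none of them adds a second ring, so the data offer no direct precedent. No step beyond the scatter is therefore expected in this assay, in either direction. The estimated change is a 1.0-fold higher number from compound 3 to compound 4 (0.01 log units; within the scatter). Compound 4 is expected at 20000 nM, with an estimated range of 8000 nM to 40000 nM.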

Compound 4, half-maximal inhibitory concentration: > 30000 nM
Compound 4: no number, only a limit; the forecaster's own chance of this, stated with the estimate: 10%; middle value at least 1.5-fold (0.17 log units) away from the limit.
By their numbers in this assay, from the lowest: compounds 3, 1 and 2 (each within the scatter of the next). At a limit, above all of these: compound 4.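

In this assay compound 4 gives > 30000 nM as a limit of the assay and not a number: the limit of > 30000 nM in this assay, at which 1 of the 4 values shown sits. With naphthalen-1-yl on the amide-type nitrogen, the steps are an at least 1.5-fold higher number from compound 3 to compound 4 (0.18 log units; that floor lies within the scatter) and an at least 1.1-fold higher number from compound 2 to compound 4 (0.06 log units; that floor lies within the scatter) and an at least 1.3-fold higher number from compound 1 to compound 4 (0.13 log units; that floor lies within the scatter) as floors only, so the true gaps may be larger. The second ring thus brings no gain in this position, yet a real loss can be neither claimed nor ruled out.

Going by these compounds, the true size of these steps stays open. So does the effect of an amine or a carboxylic acid in place of naphthalen-1-yl on the amide-type nitrogen.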